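From 4-fluorobenzyl to allyl: a small step expected

The compounds below may be only part of what the source reports. "The series", "measured", "known", "first", "only" and "open" are said of these compounds alone.

In a functional assay on J774.A1 cells (Mus musculus) for inhibition, read by Griess assay, with stated times of 1 h and 24 h (on this read-out higher numbers stand for weaker inhibition and lower numbers for stronger inhibition), compound 1 (`O=C1CC(c2ccccc2OCc2ccc(F)cc2)Oc2ccccc21`) reads 25500 nM while compound 2 (`CCCOc1ccccc1C1CC(=O)c2ccccc2O1`) reads 44600 nM and compound 3 (`CC(C)c1ccc(COc2ccccc2C2CC(=O)c3ccccc3O2)cc1`) reads 28600 nM so compound 1 stands with the other two, all within the usual scatter of one another.

Compound 4 (`C=CCOc1ccccc1C1CC(=O)c2ccccc2O1`) has not been measured yet. It carries vinyl in place of 4-fluorophenyl on a saturated chain carbon bound to an oxygen on an aromatic ring. The same difference can be read as 4-fluorobenzyl to allyl.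

The closest measured swap, ethyl in place of that 4-fluorophenyl, is a 1.7-fold higher number from compound 1 to compound 2 (0.24 log units; within the scatter) and gives the best guide. Two further swaps are a 1.1-fold higher number from compound 1 to compound 3 (0.05 log units; within the scatter) and a 1.6-fold lower number from compound 2 to compound 3 (0.19 log units; within the scatter) and neither leaves the scatter. No step beyond the scatter is therefore expected in this assay for this change. The estimated step is a 1.5-fold higher number from compound 1 to compound 4 (0.17 log units; within the scatter) and it leans the same way as the ethyl swap. Compound 4 is expected at 38000 nM with 22000 nM to 65000 nM as the estimated range.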

Compound 4, half-maximal inhibitory concentration: 38600 nM
For compound 4 the middle estimate is 1.0-fold (0.01 log units) below the measured one, and the stated range covers the measured number.
By their numbers in this assay, from the lowest: compounds 1, 3, 4 and 2 (each within the scatter of the next).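

In this assay, vinyl in place of 4-fluorophenyl gives a 1.5-fold higher number from compound 1 to compound 4 (0.18 log units; within the scatter) and vinyl in place of 4-isopropylphenyl gives a 1.3-fold higher number from compound 3 to compound 4 (0.13 log units; within the scatter), so a second group without a ring, after the ethyl swap, stays level with the compounds that carry a substituted phenyl at this position. The double bond is the new feature here: vinyl in place of ethyl gives a 1.2-fold lower number from compound 2 to compound 4 (0.06 log units; within the scatter) and leaves the number level, so in this small set a double bond outside aromatic rings makes no clear difference. No supporting data are available to explain why these numbers stay so close.

On these data alone, all four groups stay within the scatter of one another, so what would shift this read-out remains unknown. An amine, a carboxylic acid or a longer chain on the same saturated chain carbon might or might not move the number beyond that scatter.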